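Replacing the pyridin-2-yl group of compound 3

The compounds below may be only part of what the source reports. "The series", "measured", "known", "first", "only" and "open" are said of these compounds alone.

In a functional assay on MKN-45 cells (Homo sapiens) for antiproliferative activity, read by CellTiter-Glo, with a stated time of 3 days (on this read-out lower numbers stand for stronger inhibition and higher numbers for weaker inhibition), compound 3 (`C[C@@H](Oc1c(N)ncc2c(-c3ccccn3)coc12)c1c(Cl)ccc(F)c1Cl`) gives 4600 nM as its result, and compound 1 (`CC(Oc1c(N)ncc2c(-c3cnn(C4CCNCC4)c3)coc12)c1cc(F)ccc1Cl`) gives 6400 nM as its result, so these two lie within the scatter of each other. Compound 2 (`CC(Oc1c(N)ncc2c(-c3cnn(C4CCNCC4)c3)coc12)c1c(Cl)c(F)cc(F)c1Cl`) stands apart at 480 nM on the same read-out, a number lower than that of compound 3 and beyond the scatter.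

The change to compound 4 (`CC(=O)N1CC=C(c2coc3c(O[C@H](C)c4c(Cl)ccc(F)c4Cl)c(N)ncc23)CC1`) is a group of 9 heavy atoms (7 carbon, 1 nitrogen, 1 oxygen; one six-membered non-aromatic ring with 1 hetero atom) in place of a group of 6 heavy atoms (5 carbon, 1 nitrogen; one six-membered aromatic ring with 1 hetero atom), on an aromatic carbon and this place lies two ring bonds from the ring oxygen of a five-membered aromatic ring. Going by the values given here, only one measured step connects two compounds differing in a single place: a 13-fold lower number from compound 1 to compound 2 (1.12 log units; beyond the scatter) and it is large. That step, however, concerns the group on the saturated chain carbon, not the place changing here, so it offers no direct guide. Compound 2 and compound 3 differ at both places, so their gap cannot be divided between them.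

The expectation therefore stays anchored on compound 3 and its 4600 nM reading. No step beyond the scatter is expected in this assay and the estimated change is a 1.2-fold lower number from compound 3 to compound 4 (0.06 log units; within the scatter) for now. Compound 4 is estimated at 4000 nM and expected to fall from 1000 nM to 15000 nM when measured.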

Compound 4, half-maximal inhibitory concentration: 330 nM
Compound 4: middle estimate off by 12-fold (1.08 log units), on the high side, and the stated range ends above it.
By their numbers in this assay, from the lowest: compounds 4 and 2 (each within the scatter of the next); then compounds 3 and 1 (each within the scatter of the next).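

The place on the aromatic carbon, two ring bonds from the ring oxygen, turns out to be sensitive in this assay: swapping pyridin-2-yl for the larger non-aromatic six-membered ring gives a 14-fold lower number from compound 3 to compound 4 (1.14 log units; beyond the scatter), a large step beyond the scatter. Going by these compounds alone, the only step available earlier concerned the group on the saturated chain carbon, so this is the first direct reading at this place, and it shows that the aromatic pyridin-2-yl ring is not needed here for activity on these cells. Both groups count the same hydrogen-bond donors and acceptors and carry no net charge, so those counts do not separate them, and no measurement available explains the difference.

The entering group differs from pyridin-2-yl in several ways at once, including size, ring type and its carbonyl, and this single pair cannot show which of these matters. On these data alone, it also remains open whether a fully saturated piperidine ring, a plain phenyl ring or a morpholine ring at this place would read closer to compound 4 or to compound 3.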